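The source may report more compounds than this note shows. Statements on the series, on what has been measured and on what is new or still open speak of the compounds shown alone.

Among the compounds with values here, compound 3 `Cc1nn(-c2ncnc3nc[nH]c23)c2c1C(OCCn1cccn1)CC(=O)N2` stands second highest of the three numbers so far in a functional assay on HEK293 cells for agonist activity at G-protein coupled receptor 39 (Homo sapiens), read by scintillation proximity assay and inositol phosphate accumulation, with a stated time of 75 min, in the presence of a further agent that is not named here; on this read-out lower numbers stand for an effect already at smaller amounts and higher numbers for an effect only at larger amounts of compound; compound 3 gives 16 nM. Compound 1 `Cc1nn(-c2ncnc3nc[nH]c23)c2c1C(C(=O)N(C)c1nccs1)CC(=O)N2` gives 18 nM, and compound 2 `Cc1nn(-c2ncnc3nc[nH]c23)c2c1C(NC(=O)c1ccccc1)CC(=O)N2` gives 3 nM. The steps at the saturated ring carbon were a 1.1-fold lower number from compound 1 to compound 3 (0.05 log units; within the scatter), a 6.0-fold lower number from compound 1 to compound 2 (0.78 log units; beyond the scatter) and a 5.3-fold higher number from compound 2 to compound 3 (0.73 log units; beyond the scatter). Compound 4 `Cc1nn(-c2ncnc3nc[nH]c23)c2c1C(c1ccc(F)cc1Cl)CC(=O)N2` carries the change (2-chloro-4-fluorophenyl in place of 2-(1H-pyrazol-1-yl)ethoxy on a saturated ring carbon). Within the data shown here, no measured step places an aromatic ring directly on that carbon; the three measured steps only show that exchanging the group there shifts the read-out by modest amounts at most, in either direction. A step of a 1.1-fold lower number from compound 3 to compound 4 (0.03 log units; within the scatter) is therefore expected, not beyond the scatter. Compound 4 is estimated at 15 nM, with a range of 4 nM to 60 nM.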

Compound 4, half-maximal effective concentration: 9 nM
The estimate for compound 4 lay 1.7-fold (0.22 log units) above the measured number, within the range that was stated.
By their numbers in this assay, from the lowest: compound 2; then compounds 4, 3 and 1 (each within the scatter of the next).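

In this assay, an aromatic ring set directly on the saturated ring carbon is accepted: a 1.8-fold lower number from compound 3 to compound 4 (0.25 log units; within the scatter) and a 2.0-fold lower number from compound 1 to compound 4 (0.30 log units; within the scatter) both stay within the scatter, while a 3.0-fold higher number from compound 2 to compound 4 (0.48 log units; beyond the scatter) leaves the benzamido of compound 2 with the lowest number. A carbon-only ring without hydrogen-bond donors or acceptors therefore matches 2-(1H-pyrazol-1-yl)ethoxy at this place. Nothing available explains this result. Open, from the compounds shown here alone, is what an unsubstituted phenyl, an amine or a carboxylic acid on that carbon would give. Also open, going by these compounds, is how the chlorine and the fluorine of compound 4 each contribute.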